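This account rests on a few compounds, and the source may have more. Where it says the series, first, only, none or still open, it means among the compounds named here.

In a functional assay on U-937 cells (Homo sapiens) for cytotoxicity, read by CCK-8 assay, with a stated time of 72 h (a higher number here means a weaker inhibitor, a lower number a stronger inhibitor), compound 1, whose structure is `C=CCn1c(=O)/c(=C\c2cc(F)ccc2C)[nH]c(=O)/c1=C\c1ccccc1OC`, gives 1000 nM, the highest of the two numbers recorded so far. For the measured compounds named here, the only other measured compound, compound 2, with structure `COc1ccccc1/C=c1\c(=O)[nH]/c(=C/c2ccccc2Cl)c(=O)n1C`, gives 100 nM in this assay; its number is lower, and the gap lies beyond the usual scatter. Going by the values given here, compound 2 differs from compound 1 in more than one place, and no single structural step is given for that gap. Compound 3, with structure `C=CCn1c(=O)/c(=C\c2ccc(Cl)c(Cl)c2)[nH]c(=O)/c1=C\c1ccccc1OC`, has not yet been measured. It differs from compound 1 in one place: 3,4-dichlorophenyl in place of 5-fluoro-2-methylphenyl on a double-bonded chain carbon bound to an aromatic carbon. Among the compounds with values here, there is no measured step of this kind to lean on, so a change of at most modest size is expected, if anything toward a lower number. On that basis compound 3 is estimated at 600 nM in this assay, with a range from 150 nM to 2500 nM. The expected step is a 1.7-fold lower number from compound 1 to compound 3 (0.22 log units; within the scatter).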

Compound 3, half-maximal inhibitory concentration: "not active" (no number reported)
The entry for compound 3 holds no number; no gap can be computed for the estimate.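

For the compounds shown here, compound 3 is entered as "not active" without a number, and no step from compound 1 to compound 3 can be read from that entry. Nothing available helps explain this result. The compounds shown leave open how far exchanging 5-fluoro-2-methylphenyl for 3,4-dichlorophenyl shifts the number.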